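This account rests on a few compounds, and the source may have more. Where it says the series, first, only, none or still open, it means among the compounds named here.

Measured compounds:
compound 1 `C[C@@H](O)[C@H]1C(=O)N2C(C(=O)OCOC(=O)C(C)(C)C)=C(S[C@@H]3CN[C@H](C(=O)Nc4cccc(C(=O)O)c4)C3)[C@H](C)[C@H]12` gives > 95%
compound 2 `C[C@@H](O)[C@H]1C(=O)N2C(C(=O)OCC(F)(F)F)=C(S[C@@H]3CN[C@H](C(=O)Nc4cccc(C(=O)O)c4)C3)[C@H](C)[C@H]12` gives > 95%
compound 3 `C[C@@H](O)[C@H]1C(=O)N2C(C(=O)O)=C(S[C@@H]3CN[C@H](C(=O)Nc4cccc(C(=O)OCC(F)(F)F)c4)C3)[C@H](C)[C@H]12` gives > 95%

All three were tested in a physicochemical assay for metabolic stability, read by LC-MS, in phosphate buffer, with a stated time of 3 h, at pH 7.4, tested at 50 uM; on this read-out lower numbers stand for a less stable compound and higher numbers for a more stable compound. Compound 1 reaches > 95%, which is a limit of the assay and not a number. Compound 2 likewise reaches > 95%, a limit. Compound 3 also reaches > 95%, again a limit. The three values therefore sit at the same point, (the limit of > 95% in this assay, at which 3 of the 3 values shown sit), and nothing separates them.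

Compound 1 and compound 2 differ in one place: ((tert-butyl)carbonyl)oxy in place of trifluoromethyl on a saturated chain carbon bound to an oxygen next to a carbonyl group. The step that the two limits leave unreadable from compound 2 to compound 1 cannot be read, since both ends are limits. Compound 3 and compound 2 are built from the same atoms joined differently; the difference between the two cores is not broken down here.

Compound 4 `C[C@@H](O)[C@H]1C(=O)N2C(C(=O)O)=C(S[C@@H]3CN[C@H](C(=O)Nc4cccc(C(=O)OCOC(=O)C(C)(C)C)c4)C3)[C@H](C)[C@H]12` has not yet been measured in this assay. It differs from compound 3 by the same change that turns compound 2 into compound 1: ((tert-butyl)carbonyl)oxy in place of trifluoromethyl on a saturated chain carbon bound to an oxygen next to a carbonyl group. The place is the same, word for word, so the change is the same one made on a different core.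

Since the step from compound 2 to compound 1 stayed at the limit, and compound 3 already stands at the limit, compound 4 is expected to stay there as well, with an estimated step that the limit leaves unreadable from compound 3 to compound 4 from compound 3. The estimate for compound 4 is 96%, between 85% and 100%.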

Compound 4, percent of the compound remaining: > 95%
Compound 4 ended at the assay's limit; the forecaster's own chance of this, stated with the estimate: 80%; the middle value does not contradict the limit.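

In this assay compound 4 gives > 95%, which is a limit of the assay and not a number. Compound 3 also stands at a limit, so no step can be read between compound 3 and compound 4. The compounds shown leave open whether putting ((tert-butyl)carbonyl)oxy in place of trifluoromethyl makes any difference in this assay on either core, for all the values coincide: the limit of > 95% in this assay, at which 4 of the 4 values shown sit.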